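Carbocycle size on the amide nitrogen: compound 1 to compound 4

The compounds below may be only part of what the source reports. "The series", "measured", "known", "first", "only" and "open" are said of these compounds alone.

Compound 1 `CC(C)=CCC/C(C)=C/CC/C(C)=C/CSC[C@H](NC(=O)CCCCCN1CCN(C)CC1)C(=O)NC1CCCCCC1` gives 6200 nM in a functional assay on BXPC-3 cells (Homo sapiens) for cytotoxicity, read by fluorescence, with a stated time of 48 h (a higher number here means that more compound is needed for the effect, a lower number that less compound is needed), the higher of the two numbers reported, with compound 2 `CC(C)=CCC/C(C)=C/CC/C(C)=C/CSC[C@H](NC(=O)CCCCCN1CCCC1)C(=O)NC1CCCCCCC1` nearest at 4000 nM, a gap within the scatter. Compound 3 `CC(C)=CCC/C(C)=C/CC/C(C)=C/CSC[C@H](NC(=O)CCCCCN1CCCC1)C(=O)NC1CC1` reaches only a limit of the assay, > 20000 nM. Compound 4 `CC(C)=CCC/C(C)=C/CC/C(C)=C/CSC[C@H](NC(=O)CCCCCN1CCN(C)CC1)C(=O)NC1CCCCC1` differs from compound 1 by cyclohexyl in place of cycloheptyl on an amide-type nitrogen. Within the data shown here, the one measured step at this position, an at least 5.0-fold higher number from compound 2 to compound 3 (0.69 log units; beyond the scatter), runs into a limit of > 20000 nM in this assay, at which 1 of the 3 values shown sits, and concerns a far larger shrinking of the ring than here. For cycloheptyl giving way to cyclohexyl, a step of no more than the scatter is expected, if anything toward a higher number; the expected step is a 1.3-fold higher number from compound 1 to compound 4 (0.11 log units; within the scatter). Compound 4 is estimated at 8000 nM, within 3500 nM to 18000 nM.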

Compound 4, half-maximal effective concentration: 12000 nM
For compound 4 the middle estimate is 1.5-fold (0.18 log units) below the measured one; low and high end bracket the measured number.
By their numbers in this assay, from the lowest: compounds 2, 1 and 4 (each within the scatter of the next, the first and the last beyond it). At a limit, above all of these: compound 3.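

Cyclohexyl in place of cycloheptyl on the amide-type nitrogen gives a 1.9-fold higher number from compound 1 to compound 4 (0.29 log units; within the scatter) in this assay. Among these compounds, this is the first step at this position that joins two measured numbers, and within this range of ring sizes it does not exceed the scatter. Compound 3 alone remains at a limit of the assay: the limit of > 20000 nM in this assay, at which 1 of the 4 values shown sits.

Open, going by these compounds, is whether cyclopentyl or cyclobutyl on this nitrogen still gives a measured number. Also open, on these data alone, is how an open-chain group such as tert-butyl, or an aromatic phenyl, would compare with cyclohexyl.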